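The source may hold more compounds than are shown below. What is called first, only, known or untested is meant among the compounds shown, and "the series" means these compounds.

Working notes on the series. Compound 1 `C=Cc1nc2ccccc2[se]1` is the vinyl member of the first core; in a functional assay on NCI-H522 cells (Homo sapiens) for cytotoxicity, with a stated time of 3 days (a lower number here means a stronger inhibitor, a higher number a weaker inhibitor), compound 1 gives 12200 nM. Compound 2 `C#Cc1nc2ccccc2[se]1` carries ethynyl in place of vinyl on an aromatic carbon, and in this assay compound 2 gives 2170 nM, a step of a 5.6-fold lower number from compound 1 to compound 2 (0.75 log units; beyond the scatter). Compound 3 `C=Cc1nc(C(=O)OCC)cs1` is the vinyl member of the second core; the difference between the two cores is not broken down here. In this assay compound 3 reaches only the limit of the assay, > 40000 nM, so it is one of the values that sit at the limit of > 40000 nM in this assay, at which 1 of the 3 values shown sits. Compound 4 `C#Cc1nc(C(=O)OCC)cs1` is yet to be measured in this assay; it differs from compound 3 by ethynyl in place of vinyl on an aromatic carbon. The surroundings differ: in compound 3 the five-membered aromatic ring has 1 nitrogen and 1 sulfur, with the change two ring bonds from the ring atom that bears a group of 5 heavy atoms, whereas in compound 1 the ring has 1 nitrogen and 1 selenium and is part of a fused or bridged system of two rings; so this is the same kind of change, not the same. The step from compound 3 to compound 4 is expected at an at least 2.6-fold lower number from compound 3 to compound 4 (0.42 log units; beyond the scatter). Going by the values given here, this rests on compound 1 and compound 2, whose step a 5.6-fold lower number from compound 1 to compound 2 (0.75 log units; beyond the scatter) is the only measured instance of the change, while compound 3 sits at the limit of > 40000 nM in this assay, at which 1 of the 3 values shown sits, so the starting point is unknown. Compound 4 is expected near 15000 nM, between 4000 nM and 40000 nM, with a fair chance of a limit again.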

Compound 4, half-maximal inhibitory concentration: 2670 nM
Beside the measured number, compound 4's estimate is 5.6-fold (0.75 log units) above it; the whole stated range lies above it.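

In this assay, ethynyl in place of vinyl on an aromatic carbon again goes with a lower number on the second core, with an at least 14-fold lower number from compound 3 to compound 4 (1.17 log units; beyond the scatter). The direction of the change therefore carries over from the core of compound 1 to the core of compound 3, but the size of the step cannot be said to carry over or to differ: the same change on two cores in this assay, a 5.6-fold lower number (0.75 log units; beyond the scatter) from compound 1 to compound 2 and an at least 14-fold lower number (1.17 log units; beyond the scatter) from compound 3 to compound 4; the limit leaves it open whether they differ. Compound 3 gives > 40000 nM, which is a limit of the assay and not a number, and the two pairs shown are too few to establish a rule for other cores in the series.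

On these data alone, it remains open whether a nitrile or a longer alkyne chain in place of ethynyl would also go with a lower number in this assay. As far as these compounds go, it is equally open how the ethynyl step would read on the core of compound 3 with a carboxylic acid or an amide in place of the group of 5 heavy atoms.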